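A few compounds are considered here, and "the series" means these few. Any claim that something is new, unique, unknown or untested is made for them only; others in the source may bear on it.

Measured so far: compound 2 `COc1cc(C)cc(-c2nn(CC#N)cc2-c2ccnc(-c3ccc(N(C)C)cc3)c2)c1`, 549 nM; compound 1 `Cc1cc(O)cc(-c2nn(CC#N)cc2-c2ccnc(-c3ccc(Oc4ccccc4)cc3)c2)c1`, 4560 nM.

Both numbers come from a functional assay on OVCAR-4 cells (Homo sapiens) for inhibition, read by sulforhodamine B assay, with a stated time of 48 h; a higher number here means a weaker inhibitor of growth, a lower number a stronger inhibitor of growth. Compound 2 has the lowest of the two numbers, and compound 1 the higher one; the two compounds differ in more than one place, so no single step can be read between them. Compound 3 `Cc1cc(O)cc(-c2nn(CC#N)cc2-c2ccnc(-c3ccc(N(C)C)cc3)c2)c1` is still unmeasured. Going from compound 2 to compound 3 means (hydrogen in place of methyl on an oxygen on an aromatic ring). Going by the values given here, no measured pair shows this change on its own, so its size is unknown; a step no larger than the scatter is expected, as a 1.5-fold higher number from compound 2 to compound 3 (0.16 log units; within the scatter). Compound 3 is expected to give 800 nM, between 250 nM and 2500 nM.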

Compound 3, concentration for 50% growth inhibition: 4850 nM
The estimate for compound 3 lay 6.1-fold (0.78 log units) below the measured number; measured number above the stated range.
By their numbers in this assay, from the lowest: compound 2; then compounds 1 and 3 (each within the scatter of the next).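

In this assay the oxygen substituent on the aromatic ring matters: hydroxy in place of methoxy gives an 8.8-fold higher number from compound 2 to compound 3 (0.95 log units; beyond the scatter). With hydroxy present, dimethylamino in place of phenoxy gives a 1.1-fold higher number from compound 1 to compound 3 (0.03 log units; within the scatter), so the scatter cannot separate these two groups in this setting. Nothing available explains the methoxy to hydroxy step. From the compounds shown here alone, it remains open whether an ethoxy group or an amine at that place would match methoxy, and whether methoxy would give a similar step alongside phenoxy.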